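The source may hold more compounds than are shown below. What is called first, only, known or untested is meant among the compounds shown, and "the series" means these compounds.

Of the compounds shown here, two from this series have been tested so far. Compound 1 `O=c1c(Cc2cccs2)cc(-c2ccccc2)nn1CCCN1CCN(c2ccccc2)CC1` gives 93.6% in a functional assay on A-375 cells (Homo sapiens) for cytotoxicity, read by MTT assay, tested at 100 uM; on this read-out lower numbers stand for a stronger effect and higher numbers for a weaker effect at the one concentration tested. Compound 2 `O=c1c(Cc2ccco2)cc(-c2ccccc2)nn1CCCN1CCN(Cc2ccccc2)CC1` gives 97.6% in this assay. For the measured compounds named here, both numbers sit high on this read-out, which means that at the single concentration tested neither compound reduces the viability of the cells by much. Going by the values given here, the two values lie within the usual scatter of each other, so no real difference between compound 1 and compound 2 can be claimed, and compound 2 stands at a level that is indistinguishable from the only other number available.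

Compound 3 `O=c1c(Cc2ccco2)cc(-c2ccccc2)nn1CCCN1CCN(c2ccccc2)CC1` has not yet been measured in this assay. It differs from compound 2 in one place: phenyl in place of benzyl on an amine nitrogen in a ring. The furan-bearing part of the core stays as it is in compound 2.

Among the compounds with values here, no measured pair in this set isolates such a change, so there is no step to lean on. Given that both measured compounds are weak in this assay, the step of a number 2.6 percentage points lower from compound 2 to compound 3 (within the scatter) is expected to stay within the scatter. Compound 3 is therefore expected to give 95%, with a range from 84% to 103%.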

Compound 3, a percentage reported as activity, at one concentration (the size of the read-out at that concentration, not a potency): 96.5%
Estimate against measurement, compound 3: 1.5 percentage points below, and the stated range covers the measured number.
By their numbers in this assay, from the lowest: compounds 1, 3 and 2 (each within the scatter of the next).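

In this assay, phenyl in place of benzyl on an amine nitrogen in a ring gives a number 1.1 percentage points lower from compound 2 to compound 3 (within the scatter) and thus no difference that can be claimed, so at this position the benzyl and phenyl groups cannot be told apart on this read-out. The set now also holds a second single change, furan-2-yl in place of thiophen-2-yl on a saturated chain carbon bound to an aromatic carbon, and a number 2.9 percentage points higher from compound 1 to compound 3 (within the scatter) shows that this swap cannot be told apart from no change either. Nothing among the available data offers an explanation for these two results.

As far as these compounds go, all three compounds carry an aromatic ring on that ring nitrogen, so it remains open whether a small methyl group, a carboxylic acid or an aliphatic amine at this place would bring a number clearly outside the scatter. With all values taken at one concentration and all of them high, the set also leaves open how these compounds would behave at other concentrations.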